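A few compounds are considered here, and "the series" means these few. Any claim that something is new, unique, unknown or untested is made for them only; others in the source may bear on it.

In a functional assay on A549 cells (Homo sapiens) for antiproliferative activity, read by MTT assay, with a stated time of 24 h (on this read-out lower numbers stand for stronger inhibition and higher numbers for weaker inhibition), compound 2 (`C=CCc1cc(-c2ccc(OC)cc2)cc(CC=C)c1O`) gives 75600 nM. Compound 3 (`C=CC(C)(C)c1cc(-c2cccc([N+](=O)[O-])c2)ccc1O`) gives 64000 nM, and these two values lie within the usual scatter of each other. Both are large numbers on a scale where lower means stronger inhibition, so compound 2 stands among the weak inhibitors here.

The next compound to be tested is compound 4 (`C=CCc1cc(-c2ccc(OC)cc2)ccc1O`). It is compound 2 with hydrogen in place of allyl on an aromatic carbon, on the carbon ortho to a hydroxy group: hydrogen in place of allyl on an aromatic carbon.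

For the measured compounds named here, no two measured compounds differ in only one place, so this step has no direct precedent in the data. Going by the values given here, the only indirect hint is compound 1 (`C=CCc1cc(-c2cc(F)cc(F)c2)ccc1O`), which also has a hydrogen at that place, though it differs from compound 4 elsewhere too. Compound 1 gives > 100000 nM, which is a limit of the assay. On this thin basis, a small step towards weaker inhibition is expected, and it may not exceed the scatter.

The estimated change is a 1.1-fold higher number from compound 2 to compound 4 (0.05 log units; within the scatter). For compound 4, the expected value is 85000 nM, with an estimated range from 40000 nM to 170000 nM.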

Compound 4, half-maximal inhibitory concentration: > 100000 nM
Compound 4 gave a limit, no number; the forecaster's own chance of this, stated with the estimate: 40%; middle value at least 1.1-fold (0.07 log units) from the limit.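

For the compounds shown here, compound 2 and compound 4 form the first pair here that differs in one place only, so the allyl group ortho to a hydroxy group can now be judged on its own. In this assay, replacing that allyl group with hydrogen gives an at least 1.3-fold higher number from compound 2 to compound 4 (0.12 log units; that floor lies within the scatter). This points towards weaker inhibition on losing the allyl group, but only as a floor, and that floor lies within the scatter. Compound 4 stands at a limit of the assay and not at a number, so the true size of the step cannot be told: the limit of > 100000 nM in this assay, at which 2 of the 4 values shown sit.

Going by these compounds, with only allyl and hydrogen compared on this aromatic carbon, it remains open whether a longer chain, an amine or a carboxylic acid there would bring the number down or push it further up. On these data alone, it is also open whether the same swap would have a similar result in a compound whose other parts differ, since this single pair offers no second case for comparison.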